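Swapping the halogen-bearing ring in a kallikrein-7 series

The source may report more compounds than this note shows. Statements on the series, on what has been measured and on what is new or still open speak of the compounds shown alone.

Compound 2 `CC1=NC(c2cn(S(=O)(=O)c3ccc(F)cc3)c3ccc(C)cc23)CN1` is tested in an assay on isolated protein for inhibition of kallikrein-7 (Homo sapiens), read by fluorescence, with stated times of 10 min and 30 min (on this read-out lower numbers stand for stronger inhibition and higher numbers for weaker inhibition), where it gives 9400 nM. Compound 1 `CC1=NC(c2cn(S(=O)(=O)c3ccccc3)c3ccc(C)cc23)CN1` gives 17000 nM, and the step of a 1.8-fold lower number from compound 1 to compound 2 (0.26 log units; within the scatter) leaves the two standing together within the scatter. Compound 3 `CC1=NC(c2cn(S(=O)(=O)c3ccccc3Cl)c3ccc(C)cc23)CN1` carries 2-chlorophenyl in place of 4-fluorophenyl on a sulfonyl sulfur. Among the measured compounds shown here, the one step known, from compound 1 to compound 2, also touches this ring, but only by a single fluorine, and it stayed within the scatter, so no step beyond the scatter is expected for compound 3 either: the expected change is a 1.1-fold higher number from compound 2 to compound 3 (0.03 log units; within the scatter). Compound 3 is therefore estimated at 10000 nM, most likely between 4000 nM and 25000 nM.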

Compound 3, half-maximal inhibitory concentration: 1200 nM
Estimate against measurement, compound 3: 8.3-fold (0.92 log units) above; measured number outside the range, below it.
By their numbers in this assay, from the lowest: compound 3; then compounds 2 and 1 (each within the scatter of the next).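

On the ring held by the sulfonyl sulfur, this assay shows that 2-chlorophenyl in place of 4-fluorophenyl gives a 7.8-fold lower number from compound 2 to compound 3 (0.89 log units; beyond the scatter) and that chloro in place of hydrogen gives a 14-fold lower number from compound 1 to compound 3 (1.15 log units; beyond the scatter) while the earlier fluoro step stayed within the scatter. This ring can therefore move the number well beyond the scatter, and one chloro group is enough to do so. Nothing measured here accounts for the gain.

Still open, as far as these compounds go, is whether the gain follows the chlorine itself or its place on the ring: a 2-fluorophenyl or a 4-chlorophenyl group would separate the two. Also open, from the compounds shown here alone, is how an amine or a methoxy group on this ring would read.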